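The source may report more compounds than this note shows. Statements on the series, on what has been measured and on what is new or still open speak of the compounds shown alone.

Measured so far:
Compound 1, `Cc1cc(C)cc(-n2nncc2CN2C(=O)C3(C(C#N)=C(N)Oc4c3c3nc5ccccc5nc3c3ccccc43)c3ccccc32)c1`, in an ADME assay on L02 cells (Homo sapiens) for antiproliferative activity, read by MTT assay, with a stated time of 48 h (on this read-out higher numbers stand for weaker inhibition and lower numbers for stronger inhibition), gives > 50000 nM, which is a limit of the assay and not a number.
Compound 2, `N#CC1=C(N)Oc2c(N)cc3nc4ccccc4nc3c2C12C(=O)N(Cc1cnnn1-c1cccc(C(F)(F)F)c1)c1ccccc12`, in this assay gives 38100 nM.

Compound 2 thus holds the only number shown; compound 1 sits at the limit (the limit of > 50000 nM in this assay, at which 1 of the 2 values shown sits). Compound 3, `COc1cc(-n2nncc2CN2C(=O)C3(C(C#N)=C(N)Oc4c(N)cc5nc6ccccc6nc5c43)c3ccccc32)c(OC)cc1Cl`, differs from compound 2 by 4-chloro-2,5-dimethoxyphenyl in place of 3-(trifluoromethyl)phenyl on an aromatic nitrogen. Among the compounds with values here, no measured step between compounds of this kind is available, so a change beyond the usual scatter is not expected: the step of a 1.0-fold higher number from compound 2 to compound 3 (0.02 log units; within the scatter) is estimated to stay within it. Compound 3 is therefore expected to give about 40000 nM, within a range from 15000 nM to 100000 nM.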

Compound 3, half-maximal inhibitory concentration: > 50000 nM
Compound 3: no number, only a limit (the forecaster's own chance of this, stated with the estimate: 40%); at least 1.2-fold (0.09 log units) between middle value and limit.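

Putting 4-chloro-2,5-dimethoxyphenyl in place of 3-(trifluoromethyl)phenyl on the aromatic nitrogen gives an at least 1.3-fold higher number from compound 2 to compound 3 (0.11 log units; that floor lies within the scatter) in this assay, the first step seen at this position. Compound 3 gives a limit and not a number, so the step has only a floor, and its true size may or may not pass the usual scatter. That limit now recurs among the compounds shown: the limit of > 50000 nM in this assay, at which 2 of the 3 values shown sit.

Still open, as far as these compounds go, is how a phenyl ring carrying an amine or a carboxylic acid at this position would read. Also open, from the compounds shown here alone, is whether an unsubstituted phenyl would give a number at all.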